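The compounds below may be only part of what the source reports. "The series", "measured", "known", "first", "only" and "open" are said of these compounds alone.

Working notes on the series in a toxicity assay on KB cells (Homo sapiens) for cytotoxicity, read by fluorescence, with a stated time of 3 days; on this read-out lower numbers stand for an effect already at smaller amounts and higher numbers for an effect only at larger amounts of compound. Compound 3 (`CCCCOC(=O)CNC(=O)[C@H](CSc1ccc([N+](=O)[O-])cc1[N+](=O)[O-])NC(=O)CC[C@H](NC(=O)C(C)C)C(=O)OCCCC`) gives only a limit, > 300 uM. Compound 1 (`CCCCOC(=O)CNC(=O)[C@H](CSc1ccc([N+](=O)[O-])cc1[N+](=O)[O-])NC(=O)CC[C@H](NC(=O)OC)C(=O)OCCCC`) also gives only a limit, > 300 uM. This is the limit of > 300 uM in this assay, at which 2 of the 3 values shown sit. Compound 2 (`CCCCOC(=O)CNC(=O)[C@H](CSc1ccc([N+](=O)[O-])cc1[N+](=O)[O-])NC(=O)CC[C@H](NC(=O)CCC(C)C)C(=O)OCCCC`) gives a number, 84 uM.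

Compound 4 (`CCCCOC(=O)CNC(=O)[C@H](CSc1ccc([N+](=O)[O-])cc1[N+](=O)[O-])NC(=O)CC[C@H](NC(=O)/C=C/c1ccccc1)C(=O)OCCCC`) differs from compound 3 by 2-phenylethenyl in place of isopropyl on a carbonyl carbon. The steps bearing on it act on the same carbonyl carbon: an at least 3.5-fold higher number from compound 2 to compound 3 (0.55 log units; beyond the scatter) and an at least 3.5-fold lower number from compound 1 to compound 2 (0.55 log units; beyond the scatter), while a step that the two limits leave unreadable from compound 1 to compound 3. For the measured compounds named here, only isopentyl gives a measured number, so the expectation rests on the single precedent of compound 2 at 84 uM. A modest move to a lower number is expected, though a second reading at the limit remains possible. The expected change is an at least 3.3-fold lower number from compound 3 to compound 4 (0.52 log units; beyond the scatter). Compound 4 is estimated at 90 uM, with an expected range of 25 uM to 300 uM.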

Compound 4, concentration for half-maximal effect: 34.4 uM
Beside the measured number, compound 4's estimate is 2.6-fold (0.42 log units) above it, and the stated range covers the measured number.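

For the compounds shown here, on the carbonyl carbon, 2-phenylethenyl, the only group here with an aromatic ring and a double bond outside it, gives an at least 8.7-fold lower number from compound 3 to compound 4 (0.94 log units; beyond the scatter) and an at least 8.7-fold lower number from compound 1 to compound 4 (0.94 log units; beyond the scatter). Against isopentyl, the only other group with a measured number, it gives a 2.4-fold lower number from compound 2 to compound 4 (0.39 log units; beyond the scatter), so a measured number at this place no longer rests on isopentyl alone. The two steps from compounds at the limit give only a lower bound on their size: the limit of > 300 uM in this assay, at which 2 of the 4 values shown sit.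

The compounds shown leave open whether the aromatic ring or the double bond goes with the lower number. A 2-phenylethyl or a plain phenyl group on the same carbonyl carbon would separate the two.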